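A few compounds are considered here, and "the series" means these few. Any claim that something is new, unique, unknown or untested is made for them only; others in the source may bear on it.

Working notes on the series.

The shared core is a hydroxybenzyl amine carrying a varied para-substituted aniline; its substituent changes along the three measured compounds. Compound 1 `O=[N+]([O-])c1ccc(NCc2ccccc2O)cc1` in a functional assay on Jurkat cells (Homo sapiens) for activation, with a stated time of 24 h (a lower number here means that less compound is needed, a higher number that more compound is needed for the effect), gives "not active" (no number reported). Compound 2 `Oc1ccccc1CNc1ccc(N2CCCCC2)cc1` in this assay likewise gives "not active" (no number reported). Among the compounds with values here, compound 3 `Oc1ccccc1CNc1ccc(-c2ccc(Cl)cc2)cc1` in this assay gives 2390 nM; it is the only compound of the three with a number, the other two entries carrying no value at all, so no step between measured compounds can be stated.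

Compound 4 `Oc1ccccc1CNc1ccc(-c2ccc(C(F)(F)F)cc2)cc1` is not yet measured. It differs from compound 3 by trifluoromethyl in place of chloro on an aromatic carbon, with the chloro leaving and the trifluoromethyl entering at the same aromatic carbon; the rest of the molecule is unchanged. Within the data shown here, nothing among the measured compounds shows how such an exchange acts here. The expectation for compound 4 in this assay is therefore a step from compound 3 of about a 1.0-fold higher number from compound 3 to compound 4 (0.02 log units; within the scatter), which is within the scatter, with no direction asserted. Compound 4 is estimated at 2500 nM in this assay, with a range from 900 nM to 8000 nM.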

Compound 4, half-maximal effective concentration: "not active" (no number reported)
Nothing numeric was reported for compound 4, and the estimate cannot be compared.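

Within the data shown here, compound 4 carries no number, so no step from compound 3 to compound 4 can be read. The compounds shown leave open how trifluoromethyl in place of chloro acts in this assay. Nothing shown bears on this result.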